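A few compounds are considered here, and "the series" means these few. Any claim that something is new, unique, unknown or untested is made for them only; others in the source may bear on it.

Compound 1 `COc1cc(/C=C2\CN(C)C/C(=C\c3ccc(Cl)cc3)C2=O)cc(OC)c1` and compound 2 `COc1cc(/C=C2\CN(C)C/C(=C\c3ccc(Br)cc3)C2=O)cc(OC)c1` share one core; compound 3 `CN1C/C(=C\c2ccc(Cl)cc2)C(=O)/C(=C/c2ccc(C#N)cc2)C1` and compound 4 `CN1C/C(=C\c2ccc(Br)cc2)C(=O)/C(=C/c2ccc(C#N)cc2)C1` share another, and the difference between the two cores is not broken down here. In a functional assay on THP-1 cells (Homo sapiens) for cytotoxicity, read by MTT assay, with a stated time of 24 h (on this read-out higher numbers stand for weaker inhibition and lower numbers for stronger inhibition), compound 1 gives 5860 nM, compound 2 gives 4270 nM and compound 3 gives 3180 nM. The change bromo in place of chloro on an aromatic carbon made a 1.4-fold lower number from compound 1 to compound 2 (0.14 log units; within the scatter), so the two values are not told apart. The same change, (bromo in place of chloro on an aromatic carbon), is made on the other core; it occurs only twice among the compounds here, so one measured step is the whole basis. Resting on compound 3 at 3180 nM and on the step of a 1.4-fold lower number from compound 1 to compound 2 (0.14 log units; within the scatter), the expected step is a 1.3-fold lower number from compound 3 to compound 4 (0.10 log units; within the scatter), beside the earlier one. Compound 4 is estimated at 2500 nM in this assay, with the likely range from 1200 nM to 5500 nM.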

Compound 4, half-maximal inhibitory concentration: 4400 nM
Estimate against measurement, compound 4: 1.8-fold (0.25 log units) below; low and high end bracket the measured number.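

On the core of compound 3, bromo in place of chloro on an aromatic carbon gives a 1.4-fold higher number from compound 3 to compound 4 (0.14 log units; within the scatter), so the two values are not told apart in this assay. Set beside the step on the other core, this step does not differ from it: the same change on two cores in this assay, a 1.4-fold lower number (0.14 log units; within the scatter) from compound 1 to compound 2 and a 1.4-fold higher number (0.14 log units; within the scatter) from compound 3 to compound 4, 1.9-fold (0.28 log units) apart, within the scatter of two such steps. The change therefore stays within the scatter on both cores, but these two pairs cannot show whether it has the same size or direction on each, or whether it has any effect at all.

Only chloro and bromo occupy this place in the compounds shown, so it remains open whether an amine, a carboxylic acid or a trifluoromethyl group there would give a readable step. Also open, going by these compounds, is whether such a step would carry from one core to the other.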